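The source may hold more compounds than are shown below. What is called first, only, known or untested is meant among the compounds shown, and "the series" means these compounds.

Of the compounds shown here, three sharing one core have been tested in a functional assay on RAW264.7 cells (Mus musculus) for inhibition, read by ELISA, with stated times of 1 h and 18 h, tested at 20 uM; on this read-out lower numbers stand for a stronger effect and higher numbers for a weaker effect at the one concentration tested. Compound 1 `C=C1CC[C@H]2C(C)(C)CCC[C@]2(C)[C@H]1C/C=C1/C(=O)OC[C@H]1O` gives 10.8% in this assay, compound 2 `C=C1CC[C@H]2C(C)(C)CCC[C@]2(C)[C@H]1C[C@@H](O)C1=CCOC1=O` gives 47.1%, and compound 3 `C=C1CC[C@H]2C(C)(C)CCC[C@]2(C)[C@H]1C/C=C1\CC(O)OC1=O` gives 59.4%. Compound 3 therefore stands highest of the three: the nearest number, that of compound 2, lies below it by a gap beyond the usual scatter, and the number of compound 1 lies furthest below it, also well beyond the scatter. On this read-out that makes compound 3 the weakest of the three measured compounds.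

Compound 4 `C=C1CC[C@H]2C(C)(C)CCC[C@]2(C)[C@H]1C/C=C1\CC(OCC)OC1=O` has not yet been measured in this assay. It differs from compound 3 in one place: ethyl in place of hydrogen on an oxygen on a saturated carbon. Cut one bond further out, the same difference reads hydroxy to ethoxy.

Going by the values given here, no measured pair in this set shows what such a change does, so there is no step on which to rest a direction. The expectation is that the step from compound 3 to compound 4 in this assay, a number 1.4 percentage points lower from compound 3 to compound 4 (within the scatter), is of no size beyond the scatter. Compound 4 is accordingly estimated to give 58% in this assay, with a range from 35% to 80%.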

Compound 4, a percentage reported as activity, at one concentration (the size of the read-out at that concentration, not a potency): 80.9%
Compound 4: middle estimate off by 22.9 percentage points, on the low side, outside the stated range (above it).
By their numbers in this assay, from the lowest: compound 1; then compound 2; then compound 3; then compound 4.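

In this assay, going by these compounds alone, the move from hydroxy to ethoxy gives the first measured reading of this change: a number 21.5 percentage points higher from compound 3 to compound 4 (beyond the scatter), which on this read-out means a weaker effect at the one concentration tested. The earlier compounds shown here formed no pair differing in one place, whereas this step shows that the oxygen on a saturated carbon is not indifferent to what it carries, since ethyl in place of hydrogen there moves the number beyond the usual scatter. The data offer no measured explanation for the direction or size of this step.

The compounds shown leave open whether this step belongs to ethyl in particular or would follow any replacement of the hydrogen on that oxygen, such as methyl, a longer chain such as butyl, or an acetyl group. Also open, going by these compounds, is whether ethyl on the hydroxy of compound 1 or compound 2 would move the number the same way, so the step holds for this one pair alone.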